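Cyclohexyl for 3-fluorophenyl on a chromene amide series

A few compounds are considered here, and "the series" means these few. Any claim that something is new, unique, unknown or untested is made for them only; others in the source may bear on it.

Compound 1 `O=C(O)C1=Cc2ccccc2OC1(OCc1cc(-c2ccc(F)cc2)no1)C(F)(F)F` gives > 150000 nM in a functional assay on HeLa cells (Homo sapiens) for inhibition, read by MTT assay, with a stated time of 24 h (a lower number here means a stronger inhibitor, a higher number a weaker inhibitor), which is a limit of the assay.
Compound 2 `CCOC(=O)C1=Cc2ccccc2OC1(OCc1cn(CC(=O)Nc2cccc(F)c2)nn1)C(F)(F)F` gives > 150000 nM in this assay, again a limit.
Compound 3 `O=C(O)C1=Cc2ccccc2OC1(OCc1cc(-c2ccc(F)cc2F)no1)C(F)(F)F` gives > 150000 nM in this assay, also a limit.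

Compound 2 therefore stands at the limit, like every other measured compound; (the limit of > 150000 nM in this assay, at which 3 of the 3 values shown sit). Within the data shown here, the only step measured so far, a step that the two limits leave unreadable from compound 1 to compound 3, runs between two limits and says nothing about size, and it concerns a different change than the one considered here. Compound 4 `CCOC(=O)C1=Cc2ccccc2OC1(OCc1cn(CC(=O)NC2CCCCC2)nn1)C(F)(F)F` differs from compound 2 by cyclohexyl in place of 3-fluorophenyl on an amide-type nitrogen. Among the measured compounds shown here, no measured step bears on this change, so the expectation rests on where compound 2 stands. Compound 4 is expected to remain at the limit of this assay, with a step that the limit leaves unreadable from compound 2 to compound 4 as the estimated step, which is no step beyond the scatter. Compound 4 is estimated at 200000 nM, within 60000 nM to 700000 nM.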

Compound 4, half-maximal inhibitory concentration: 11400 nM
Compound 4: the middle estimate sits 18-fold (1.24 log units) above what was measured; the measured number lies below the stated range.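

Among these compounds, the change from 3-fluorophenyl to cyclohexyl on the amide-type nitrogen gives an at least 13-fold lower number from compound 2 to compound 4 (1.11 log units; beyond the scatter), the first sign that the group at this position can move the result in this assay. The swap removes an aromatic ring and a fluorine together and puts a non-aromatic ring of carbon in their place, and this alone separates an inactive-looking compound from a measurable one. Compound 4 is also the only compound shown whose value is a number rather than a limit: the limit of > 150000 nM in this assay, at which 3 of the 4 values shown sit.

The pair cannot separate the part played by the fluorine from that of the ring, so plain phenyl on the same nitrogen would be informative, as would cyclopentyl or a straight hexyl chain. On these data alone, whether cyclohexyl still gives a measurable value with a carboxylic acid in place of the ethyl ester also remains open.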